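A few compounds are considered here, and "the series" means these few. Any claim that something is new, unique, unknown or untested is made for them only; others in the source may bear on it.

Compound 1 `Cn1ccc2c(Oc3ccc(NC(=O)c4nn(-c5ccc(Cl)cc5)ccc4=O)cc3)ccnc21`. In a functional assay on PC-3 cells (Homo sapiens) for cytotoxicity, read by MTT assay, with a stated time of 72 h (a lower number here means a stronger inhibitor, a higher number a weaker inhibitor), compound 1 gives > 60000 nM, which is a limit of the assay rather than a number.
Compound 2 `COc1ccc(-n2ccc(=O)c(C(=O)Nc3ccc(Oc4ccnc5c4ccn5C)cc3)n2)cc1`. In this assay compound 2 gives > 60000 nM, again a limit and not a number.

Among the measured compounds shown here, compound 2 therefore stands at the limit, alongside the only other measured compound. For the measured compounds named here, the single measured step, a step that the two limits leave unreadable from compound 1 to compound 2, cannot be read for size, since both of its ends sit at the limit described by the limit of > 60000 nM in this assay, at which 2 of the 2 values shown sit. Compound 3 `Cn1ccc2c(Oc3ccc(NC(=O)c4nn(-c5ccc(Br)cc5)ccc4=O)cc3)ccnc21` differs from compound 2 by bromo in place of methoxy on an aromatic carbon. Going by the values given here, no measured step gives a readable size for this change, so the expectation rests on both known compounds sitting at the limit. Compound 3 is estimated at 70000 nM in this assay, with a range from 15000 nM to 250000 nM. This estimate means a step that the limit leaves unreadable from compound 2 to compound 3, and most likely the assay will again report only a limit for compound 3.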

Compound 3, half-maximal inhibitory concentration: 23000 nM
The estimate for compound 3 lay 3.0-fold (0.48 log units) above the measured number; the range from low to high includes it.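

Bromo in place of methoxy gives an at least 2.6-fold lower number from compound 2 to compound 3 (0.41 log units; beyond the scatter) in this assay, and bromo in place of chloro gives an at least 2.6-fold lower number from compound 1 to compound 3 (0.41 log units; beyond the scatter) on the same aromatic carbon, para to a large group, so a change at this place can shift the result by a readable amount. Among the compounds shown here, the earlier step, methoxy in place of chloro, could not be read, which makes bromo the first group here to separate itself from the others. Both new steps give only a minimum size, because their starting compounds are limits and not numbers: the limit of > 60000 nM in this assay, at which 2 of the 3 values shown sit.

As far as these compounds go, how far chloro and methoxy lie from each other therefore stays open, as does the true size of either step. From the compounds shown here alone, it is also open whether iodo, trifluoromethyl or an amine at this place would give a lower number than bromo.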